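Compound 2 and the Pyrazole Replacement Leading to Compound 4

A few compounds are considered here, and "the series" means these few. Any claim that something is new, unique, unknown or untested is made for them only; others in the source may bear on it.

The study concerns a functional assay for antagonist activity at Neuropeptides B/W receptor type 1 (Homo sapiens), read by cAMP accumulation; on this read-out higher numbers stand for weaker inhibition and lower numbers for stronger inhibition. Three compounds have numbers. Compound 1, `O=[N+]([O-])c1ccc2[nH]c(-c3ccccc3N3CCCC3)nc2c1`, gives 6770 nM. Compound 3, `O=[N+]([O-])c1ccc2[nH]c(-c3cccc(Cl)c3)nc2c1`, gives 9980 nM. Compound 2, `FC(F)(F)c1ccc2[nH]c(-c3ccc(-c4nnc[nH]4)cc3)nc2c1`, gives 3080 nM, the lowest of the three and therefore the most potent inhibitor in this assay; compound 1 is its nearest neighbour at a higher number, and compound 3 stands further away, both gaps lying beyond the scatter of repeated measurements.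

The piece now follows a single change made on compound 2. The new compound, compound 4, is `Cn1cc(-c2ccc(-c3nc4cc(C(F)(F)F)ccc4[nH]3)cc2)cn1`. The difference, computed from the two structures, is 1-methyl-1H-pyrazol-4-yl in place of 4H-1,2,4-triazol-3-yl on an aromatic carbon. In words, a 1-methyl-1H-pyrazol-4-yl replaces a 4H-1,2,4-triazol-3-yl on an aromatic carbon of a six-membered aromatic ring of carbon only, para to a large group.

Among the compounds with values here, no pair of measured compounds here differs in just one place, so no comparable step exists to lean on. Given only the value of compound 2 and the nature of the swap, a modest step is expected, if any, toward a somewhat higher number, not clearly beyond the scatter. The expected step is a 1.4-fold higher number from compound 2 to compound 4 (0.13 log units; within the scatter). Compound 4 is therefore estimated at 4200 nM, with a range from 1500 nM to 12000 nM.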

Compound 4, half-maximal inhibitory concentration: 1470 nM
Compound 4: the middle estimate sits 2.9-fold (0.46 log units) above what was measured; measured number below the stated range.
By their numbers in this assay, from the lowest: compound 4; then compound 2; then compounds 1 and 3 (each within the scatter of the next).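

In this assay, within the data shown here, putting a 1-methyl-1H-pyrazol-4-yl in place of a 4H-1,2,4-triazol-3-yl on this aromatic carbon gives a 2.1-fold lower number from compound 2 to compound 4 (0.32 log units; beyond the scatter), the first single-place change in the set and one that lies beyond the scatter. The entering group has 0 hydrogen-bond donors where the leaving group has 1 hydrogen-bond donor, so in this pair a donor on the five-membered aromatic ring is not needed to hold inhibition at this level, and the position accepts a group of 6 heavy atoms in place of one of 5. Nothing available here explains the lower number.

The swap changes the ring and adds a methyl in one move, so these compounds cannot say which part carries the step; a 1H-pyrazol-4-yl without that methyl would separate the two. Also open, going by these compounds, is how this carbon responds to groups of another kind, such as an amine or a carboxylic acid, and whether the same swap would act alike with a nitro group in place of the trifluoromethyl on the core.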